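A few compounds are considered here, and "the series" means these few. Any claim that something is new, unique, unknown or untested is made for them only; others in the source may bear on it.

Working notes on the series. Compound 1 `CN(C)CCCNc1nc(N)nc2cc(-c3ccc(C(F)(F)F)cc3)sc12` gives 148 ug/mL in a physicochemical assay for solubility, in phosphate buffer, at pH 6.5; a higher number here means a more soluble compound, a lower number a less soluble compound. Compound 2 `Nc1nc(NC2CCNC2)c2sc(-c3ccc(C(F)(F)F)cc3)cc2n1` gives 155 ug/mL in this assay, the two values being separated by a 1.0-fold higher number from compound 1 to compound 2 (0.02 log units; within the scatter). Compound 3 `Nc1nc(NC2CCOCC2)c2sc(-c3ccc(C(F)(F)F)cc3)cc2n1` is recorded in this assay only as a limit, < 5 ug/mL. Compound 3 therefore stands at the bottom of the three numbers shown: the steps into it are an at least 29-fold lower number from compound 1 to compound 3 (1.47 log units; beyond the scatter) and an at least 31-fold lower number from compound 2 to compound 3 (1.49 log units; beyond the scatter), both large, and its value sits at the limit of < 5 ug/mL in this assay, at which 1 of the 3 values shown sits.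

Compound 4 `Nc1nc(N2CCC(N)CC2)c2sc(-c3ccc(C(F)(F)F)cc3)cc2n1` is not yet measured. Its change from compound 3 is 4-aminopiperidin-1-yl in place of (oxan-4-yl)amino on an aromatic carbon. Among the measured compounds shown here, no measured step covers this exact change. The two steps that bear on it are an at least 29-fold lower number from compound 1 to compound 3 (1.47 log units; beyond the scatter) and an at least 31-fold lower number from compound 2 to compound 3 (1.49 log units; beyond the scatter), in which a 3-(dimethylamino)propyl chain or a pyrrolidin-3-yl ring gave way to oxan-4-yl and the number fell by a large amount. Compound 4 brings an amine-bearing ring back in place of oxan-4-yl, so a large step in the opposite direction is expected. Compound 4 is thus expected at 100 ug/mL, within 30 ug/mL to 300 ug/mL. The expected step is an at least 20-fold higher number from compound 3 to compound 4 (1.30 log units; beyond the scatter), its true size uncertain as compound 3 is only a limit.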

Compound 4, solubility: 134 ug/mL
Compound 4: the middle estimate sits 1.3-fold (0.13 log units) below what was measured; measured number inside the range.
By their numbers in this assay, from the lowest: compounds 4, 1 and 2 (each within the scatter of the next). At a limit, below all of these: compound 3.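

In this assay, this change at the aromatic carbon gives an at least 26-fold higher number from compound 3 to compound 4 (1.42 log units; beyond the scatter), although the two groups match in their counts of heavy atoms, donors and acceptors and differ by one oxygen giving way to one nitrogen. Compound 3 remains a limit: the limit of < 5 ug/mL in this assay, at which 1 of the 4 values shown sits.

Compound 4 joins its ring to the aromatic carbon through the ring nitrogen, not through an amino link, yet it stands level with the two earlier amine-bearing compounds: a 1.2-fold lower number from compound 2 to compound 4 (0.06 log units; within the scatter) and a 1.1-fold lower number from compound 1 to compound 4 (0.04 log units; within the scatter).

From the compounds shown here alone, it remains open whether the amino group on the ring accounts for the gap to compound 3, which a plain piperidin-1-yl ring or a 4-hydroxypiperidin-1-yl ring at this place would address. A carboxylic acid on the same ring would show whether a group other than an amine gives similar numbers.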